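A shorter chain beside the ring nitrogen: compound 4

The compounds below may be only part of what the source reports. "The series", "measured", "known", "first", "only" and "open" are said of these compounds alone.

Three compounds have numbers in an assay for inhibition of leukotriene C4 synthase (Homo sapiens), read by LC-MS, with stated times of 15 min and 30 min; on this read-out lower numbers stand for stronger inhibition and higher numbers for weaker inhibition. Compound 1 `COc1cc(N(CC2CC2)c2ccc(Cl)c3ccccc23)cnc1C(=O)[C@H]1C[C@@H]1C(=O)O` gives 1.41 nM, compound 2 `COc1cc(N(CC2CC2)c2ccccc2)cnc1C(=O)[C@H]1C[C@@H]1C(=O)O` gives 158 nM, and compound 3 `COc1cc(N(CC(C)C)c2ccc(F)c3ccccc23)cnc1C(=O)[C@H]1C[C@@H]1C(=O)O` gives 0.381 nM. On these numbers compound 3 stands lowest of the three; its nearest neighbour is compound 1, whose number is higher by a margin beyond the usual scatter, and compound 2 lies far further away, also beyond the scatter. Compound 4 `CCN(c1cnc(C(=O)[C@H]2C[C@@H]2C(=O)O)c(OC)c1)c1ccc(F)c2ccccc12` has not been measured in this assay. It differs from compound 3 in one place: methyl in place of isopropyl on a saturated chain carbon bound to a nitrogen on an aromatic ring. Going by the values given here, no pair of measured compounds shows this change on its own, so the size of the step cannot be read from a measured pair. The chain that leaves is larger than the one that enters, and compound 1, which carries a different chain and a different halogen, gives 1.41 nM, a somewhat higher number than compound 3. A modest rise in the number is therefore expected, with a step of a 2.9-fold higher number from compound 3 to compound 4 (0.46 log units; beyond the scatter) that goes somewhat beyond the scatter. Compound 4 is estimated at 1.1 nM, with a range from 0.3 nM to 4 nM.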

Compound 4, half-maximal inhibitory concentration in the leukotriene C4 synthase assay: 1.05 nM
Beside the measured number, compound 4's estimate is 1.0-fold (0.02 log units) above it, within the range that was stated.
By their numbers in the leukotriene C4 synthase assay, from the lowest: compound 3; then compounds 4 and 1 (each within the scatter of the next); then compound 2.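

Going by these compounds alone, in the leukotriene C4 synthase assay, methyl in place of isopropyl on a saturated chain carbon bound to a nitrogen on an aromatic ring gives a 2.8-fold higher number from compound 3 to compound 4 (0.44 log units; beyond the scatter), which is the first measured step for a change at this place alone. The shorter chain therefore costs inhibition, but only modestly, so the isobutyl of compound 3 is not essential to a low number here. In a physicochemical assay for lipophilicity, read by LC-MS, in phosphate buffer, measured as octanol-water partition, at pH 7.4 (on this read-out higher numbers stand for higher lipophilicity and lower numbers for lower lipophilicity), compound 3 gives 2.2 and compound 4 gives 1.4. The same change thus also moves the number in the physicochemical assay: the measured distribution coefficient of compound 3, 2.2, and of compound 4, 1.4, a number 0.80 log units lower (beyond the scatter)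

Whether these two shifts are linked cannot be told from this single pair. As far as these compounds go, how a propyl chain, or a chain carrying a hydroxyl group or an amine, would read at this place stays open, as does the separate contribution of the chain and the halogen in compound 1.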